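The source may hold more compounds than are shown below. What is called first, only, known or untested is meant among the compounds shown, and "the series" means these compounds.

Measured so far in one assay (a functional assay on HeLa cells (Homo sapiens) for antiproliferative activity, read by MTT assay, with a stated time of 72 h; on this read-out lower numbers stand for stronger inhibition and higher numbers for weaker inhibition):

- Compound 1 (`COc1ncc(-c2ccc3c(c2)N(c2ccc(C)cc2)C(=O)CO3)cc1NS(=O)(=O)c1ccc(F)cc1`) gives 4650 nM as its value.
- Compound 2 (`COc1cccc(N2C(=O)COc3ccc(-c4cccc(NS(=O)(=O)c5ccc(F)cc5)c4)cc32)c1`) gives > 40000 nM as its reading, which is a limit and not a number.

Compound 2 therefore stands only at a limit of this assay and has no exact place on the scale. The next compound, compound 3 (`O=C1COc2ccc(-c3cccc(NS(=O)(=O)c4ccc(F)cc4)c3)cc2N1c1ccc(Cl)cc1`), departs from it by a single change (4-chlorophenyl in place of 3-methoxyphenyl on an amide-type nitrogen in a ring): 4-chlorophenyl in place of 3-methoxyphenyl on an amide-type nitrogen in a ring. Going by the values given here, no measured pair shows what such a change does. Compound 1 has a numerical value (4650 nM), but it differs from compound 2 in more than this one place, so it offers no direct guide. Only a modest step towards stronger inhibition is expected (an at least 1.3-fold lower number from compound 2 to compound 3 (0.12 log units; that floor lies within the scatter)), and the assay may again report only a limit. Compound 3 is expected to give 30000 nM in this assay with an estimated range (10000 nM to 60000 nM).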

Compound 3, half-maximal inhibitory concentration: 35000 nM
Beside the measured number, compound 3's estimate is 1.2-fold (0.07 log units) below it; the measured number falls inside the stated range.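

At the amide-type nitrogen, 4-chlorophenyl in place of 3-methoxyphenyl gives an at least 1.1-fold lower number from compound 2 to compound 3 (0.05 log units; that floor lies within the scatter). Compound 3 gives 35000 nM in this assay, so this position now has an exact reading on the scale for a compound with the core of compound 2. Compound 2 reads only as a limit, and because of this the true size of the step stays unknown: the limit of > 40000 nM in this assay, at which 1 of the 3 values shown sits.

The compounds shown leave open whether the step belongs to the chlorine itself or to the different place of the group on the phenyl ring, a question that 3-chlorophenyl or 4-methoxyphenyl at this nitrogen would address. They also leave open how an amine or a carboxylic acid on that phenyl ring would read in this assay.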